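The compounds below may be only part of what the source reports. "The series", "measured", "known", "first", "only" and "open" are said of these compounds alone.

Measured compounds:
Compound 1 `CC(=O)N1CCC(c2ccc3c(c2)oc(=O)n3C(=O)NCCCCc2ccccc2)CC1` gives 1 h in an ADME assay on microsomes from liver (Mus musculus) for metabolic stability, read by LC-MS, using NADPH, with stated times of 15 min and 60 min, tested at 4.6 uM; on this read-out higher numbers stand for a longer-lived compound and lower numbers for a shorter-lived compound.
Compound 2 `CN1CCN(c2ccc3c(c2)oc(=O)n3C(=O)NCCCCc2ccccc2)C(=O)C1` gives only a limit, < 0.0834 h, in this assay.
Compound 3 `CC(C)CNC(=O)n1c(=O)oc2cc(C3CCCN(C)C3)ccc21` likewise gives only a limit, > 1 h, in this assay.

Among these three, compound 1 is the only compound with a numerical value; the other two sit at limits, one at the limit of < 0.0834 h in this assay, at which 1 of the 3 values shown sits, and one at the limit of > 1 h in this assay, at which 1 of the 3 values shown sits. Compound 4 `CN1CCC(c2ccc3c(c2)oc(=O)n3C(=O)NCCCCc2ccccc2)CC1` has not yet been measured. It differs from compound 1 by methyl in place of acetyl on an amine nitrogen in a ring.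

Among the measured compounds shown here, the single measured step, an at least 11-fold lower number from compound 1 to compound 2 (1.07 log units; beyond the scatter), concerns a different change, the ring itself being replaced, and so bears only loosely on the methyl for acetyl exchange. For the measured compounds named here, compound 3 carries a methyl on a ring amine nitrogen and stands at a limit, but no step to it is known. On this evidence no step beyond the scatter is expected from compound 1 to compound 4, though the scarce data leave the direction open. Compound 4 is therefore estimated at 0.7 h, within 0.2 h to 2 h, a step of a 1.4-fold lower number from compound 1 to compound 4 (0.15 log units; within the scatter) expected.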

Compound 4, half-life: 0.667 h
Beside the measured number, compound 4's estimate is 1.0-fold (0.02 log units) above it; low and high end bracket the measured number.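

In this assay, methyl in place of acetyl on the amine nitrogen in the ring gives a 1.5-fold lower number from compound 1 to compound 4 (0.18 log units; within the scatter), so the two compounds cannot be told apart and the acetyl carbonyl is not needed to hold this half-life. With the methyl group kept, 1-methylpiperidin-4-yl in place of 4-methyl-2-oxopiperazin-1-yl gives an at least 7.9-fold higher number from compound 2 to compound 4 (0.90 log units; beyond the scatter), which ties the short half-life of compound 2 to that ring and not to the methyl group it shares with compound 4. Compound 2 stands at a limit and not at a number: the limit of < 0.0834 h in this assay, at which 1 of the 4 values shown sits.

From the compounds shown here alone, what a free ring amine, a methanesulfonyl group or a longer chain on this nitrogen would give remains open. Among the compounds shown here, compound 3 differs from the others in more than one place, so no step to it can be read, and it also stands at a limit: the limit of > 1 h in this assay, at which 1 of the 4 values shown sits.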